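The source may hold more compounds than are shown below. What is called first, only, known or untested is meant among the compounds shown, and "the series" means these compounds.

Measured so far in a functional assay on MIA PaCa-2 cells (Homo sapiens) for antiproliferative activity, read by sulforhodamine B assay, with a stated time of 48 h (a higher number here means a weaker inhibitor, a lower number a stronger inhibitor), are two compounds:

Compound 1 `COc1ccc2nc(-c3ccc(N/C=C\C(=O)c4cc(OC)c(OC)c(OC)c4)cc3)sc2c1` gives 31100 nM
Compound 2 `COc1ccc2nc(-c3ccc(N/C=C\C(=O)c4cc(OC)c(OC)c(OC)c4Br)c(C)c3)sc2c1` gives 23400 nM

These two numbers lie within the scatter of each other, so compound 2 stands level with compound 1 and the pair cannot be ranked. Compound 3 `COc1ccc2nc(-c3ccc(N/C=C\C(=O)c4cc(OC)c(OC)c(OC)c4Br)cc3)sc2c1` has not yet been measured. It differs from compound 2 at a single place, with hydrogen in place of methyl on an aromatic carbon, as counted in hydrogen in place of methyl on an aromatic carbon and located on a six-membered aromatic ring of carbon only. Within the data shown here, no measured pair isolates this change, so the data give no direct guide to its size. Compound 1 also carries hydrogen on that carbon and differs from compound 2 in a further place, yet compound 1 at 31100 nM remains within the scatter of compound 2 in this assay as measured. On that basis the expected step of a 1.0-fold higher number from compound 2 to compound 3 (0.01 log units; within the scatter) is none beyond the scatter, with no direction favoured. For compound 3 the estimated value is 24000 nM with an expected range from 9000 nM to 60000 nM in this measurement.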

Compound 3, half-maximal inhibitory concentration: 14700 nM
Compound 3: the middle estimate sits 1.6-fold (0.21 log units) above what was measured; measured number inside the range.
By their numbers in this assay, from the lowest: compounds 3, 2 and 1 (each within the scatter of the next, the first and the last beyond it).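

In this assay, among these compounds, the swap of methyl for hydrogen on the aromatic carbon ortho to a large group and meta to the 6-methoxy-1,3-benzothiazol-2-yl group gives the first single-place reading at this position, and it stays within the scatter (a 1.6-fold lower number from compound 2 to compound 3 (0.20 log units; within the scatter)), so this pair shows no measurable effect of the methyl group there. Compound 3 also provides the first single-place comparison for bromo, and bromo in place of hydrogen on an aromatic carbon gives a modest step that goes beyond the scatter (a 2.1-fold lower number from compound 1 to compound 3 (0.33 log units; beyond the scatter)), which makes this the only change among the compounds shown with a readable effect in this assay. No measurement shown here accounts for either step.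

The compounds shown leave open whether the bromo step would hold with methyl on the carbon ortho to a large group, since that reading rests on a single pair. They also leave open how an amine, a carboxylic acid or a longer chain such as propyl on that same carbon would compare with hydrogen and methyl.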